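Estimating compound 4 from a single measured neighbour

The source may hold more compounds than are shown below. What is called first, only, known or untested is meant among the compounds shown, and "the series" means these compounds.

Measured in a functional assay on A-431 cells (Homo sapiens) for antiproliferative activity, read by MTT assay, with a stated time of 72 h; on this read-out higher numbers stand for weaker inhibition and lower numbers for stronger inhibition:
- compound 1 `CN1CCN(c2ccc(Nc3ncc4nc(Nc5ccc(F)cc5)n([C@@H]5CCN(C(=O)CO)C5)c4n3)cc2)CC1`: "not determined" (no result reported)
- compound 2 `CN1CCN(c2ccc(Nc3ncc4nc(Nc5ccc(F)cc5)n(-c5cccc(NC(=O)CO)c5)c4n3)cc2)CC1`: 1670 nM
- compound 3 `CN1CCN(c2ccc(Nc3ncc4nc(Nc5ccccc5)n([C@@H]5CCNC5)c4n3)cc2)CC1`: "not determined" (no result reported)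

Compound 3 has no single number in this assay, so it cannot be ranked, and compound 1 is in the same position. Compound 4 `CN1CCN(c2ccc(Nc3ncc4nc(Nc5ccccc5)n([C@H]5CCN(S(=O)(=O)C6CC6)C5)c4n3)cc2)CC1` has 1-(cyclopropylsulfonyl)pyrrolidin-3-yl in place of pyrrolidin-3-yl on an aromatic nitrogen. Going by the values given here, no measured step shows what such a change does, so the size and direction of any shift in this assay stay open, and no step beyond the scatter can be expected with confidence. Among the compounds with values here, the only anchor is compound 2 at 1670 nM, a loose one since its group differs. For compound 4 the estimated value is 1500 nM, with an expected range of 400 nM to 5500 nM.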

Compound 4, half-maximal inhibitory concentration: 1670 nM
Compound 4: middle estimate off by 1.1-fold (0.05 log units), on the low side; measured number inside the range.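

Compound 3 has no single number in this assay to set beside compound 4, so no new step can be read. The compounds shown leave open what 1-(cyclopropylsulfonyl)pyrrolidin-3-yl in place of pyrrolidin-3-yl does to activity. No evidence bears on this result.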